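A few compounds are considered here, and "the series" means these few. Any claim that something is new, unique, unknown or untested is made for them only; others in the source may bear on it.

Measured so far in a functional assay on NCI-H23 cells (Homo sapiens) for cytotoxicity, read by sulforhodamine B assay, with a stated time of 48 h, tested at 100 nM; a higher number here means a weaker effect of the compound at the concentration tested, a lower number a stronger effect:
compound 1 `COc1cc(C)cc(-c2nn(CC#N)cc2-c2ccc(-c3cccc(C(C)=O)c3)nc2)c1`: 88%
compound 2 `Cc1cc(O)cc(-c2nn(CC#N)cc2-c2ccnc(-c3ccc(Oc4ccccc4)cc3)c2)c1`: 96%
compound 3 `COc1cc(C)cc(-c2nn(CC#N)cc2-c2ccnc(-c3ccc(N(C)C)cc3)c2)c1`: 31%

Compound 3 stands lowest of the three numbers in this assay, so it shows the strongest effect at the concentration tested; its nearest neighbour is compound 1 and its furthest is compound 2, both gaps beyond the scatter. Going by the values given here, compounds 1 and 2 differ from compound 3 in more than one place, so no single step between measured compounds is available.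

Compound 4 `Cc1cc(O)cc(-c2nn(CC#N)cc2-c2ccnc(-c3ccc(N(C)C)cc3)c2)c1` has not been measured. The change from compound 3 is hydrogen in place of methyl on an oxygen on an aromatic ring. Among the compounds with values here, with no comparable step in hand, the expected step of a number 14 percentage points higher from compound 3 to compound 4 (beyond the scatter) is small, a modest weakening at most, possibly none beyond the scatter. Compound 4 is estimated at 45%, within 20% to 75%.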

Compound 4, a percentage reported as activity, at one concentration (the size of the read-out at that concentration, not a potency): 98%
Compound 4: middle estimate off by 53 percentage points, on the low side; the whole stated range lies below it.
By their numbers in this assay, from the lowest: compound 3; then compounds 1, 2 and 4 (each within the scatter of the next).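

In this assay, going by these compounds alone, methoxy to hydroxy on the 3-methoxy-5-methylphenyl gives a number 67 percentage points higher from compound 3 to compound 4 (beyond the scatter) and is the first single-place change read at this position, so the effect at the concentration tested depends heavily on that methyl on oxygen when dimethylamino is present. With hydroxy in place, dimethylamino in place of phenoxy gives a number 2 percentage points higher from compound 2 to compound 4 (within the scatter) and so does not separate these two compounds. Still open, going by these compounds, is whether ethoxy or an amine at this place would keep the effect, and whether methoxy would do so alongside phenoxy. No measurement shown here explains the size of the methoxy to hydroxy step.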